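The compounds below may be only part of what the source reports. "The series", "measured", "known", "first", "only" and "open" are said of these compounds alone.

Measured so far:
Compound 1 `CC(=O)SCCC(CCCCC(=O)O)SC(C)=O`: 7.24%
Compound 2 `COc1ccc(NC(=O)CCCCC(S)CCS)cc1`: "not active" (no number reported)
Compound 3 `CC(=O)SCCC(CCCCC(=O)Nc1ccccc1)SC(C)=O`: 7.24%

In a functional assay on KB cells (Homo sapiens) for inhibition, read by MTT assay, with a stated time of 24 h, tested at 0.1 ug/mL (on this read-out lower numbers stand for less inhibition of growth and higher numbers for more inhibition of growth at the one concentration tested), compound 3 gives 7.24%, level with compound 1 at 7.24%. Compound 4 `CC(=O)SCCC(CCCCC(=O)Nc1ccccc1Cl)SC(C)=O` follows from compound 3 by one change: chloro in place of hydrogen on an aromatic carbon. Going by the values given here, the only measured step nearby is no change at the digits printed from compound 1 to compound 3 (within the scatter), for anilino in place of hydroxy on a carbonyl carbon. Among the compounds with values here, no measured step involves chloro, so the data give no sign of a direction, and no shift beyond the scatter is expected. The expected step is a number 0.8 percentage points higher from compound 3 to compound 4 (within the scatter). For compound 4 the estimate is 8%, with an expected range from 2% to 18%.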

Compound 4, percent growth inhibition at one concentration: 7.05%
Estimate against measurement, compound 4: 1 percentage points above, within the range that was stated.
By their numbers in this assay, from the lowest: compounds 4, 1 and 3 (each within the scatter of the next).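

In this assay, going by these compounds alone, chloro on an aromatic carbon of the six-membered ring, ortho to a large group, gives a number 0.2 percentage points lower from compound 3 to compound 4 (within the scatter), the first evidence that this ring position can be substituted without moving the read-out beyond the scatter. The (2-chlorophenyl)amino group in place of hydroxy on the carbonyl carbon likewise gives a number 0.2 percentage points lower from compound 1 to compound 4 (within the scatter), so it does not separate compound 4 from the parent acid at this one concentration. Nothing available explains this result. Going by these compounds, whether a nitro or fluoro group at this place would behave as chloro does remains open. So does whether any such compound would separate from the others at a higher concentration.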